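Fluoro Added to the Chlorophenyl Group of Compound 2

This account rests on a few compounds, and the source may have more. Where it says the series, first, only, none or still open, it means among the compounds named here.

Within the data shown here, compound 2 `C[C@H](c1ccc(C(=O)NCCC(=O)O)cc1)N1C(=O)C(c2cccc(Cl)c2)=N[C@]12CC[C@@H](C(C)(C)C)CC2` gives 130 nM in an assay on CHO cells for displacement of a labelled ligand from Glucagon receptor (Homo sapiens), read by scintillation counting, with a stated time of 60 min (on this read-out higher numbers stand for weaker inhibition and lower numbers for stronger inhibition), the lowest of the three numbers measured so far. Compound 1 `C[C@H](c1ccc(C(=O)NCCC(=O)O)cc1)N1C(=O)C(c2ccccc2F)=N[C@]12CC[C@@H](C(C)(C)C)CC2` gives 1100 nM, and compound 3 `CC(C)(C)[C@H]1CC[C@]2(CC1)N=C(c1cccc(Cl)c1)C(=O)N2Cc1ccc(C(=O)NCCC(=O)O)cc1` gives 770 nM. Compound 4 `C[C@H](c1ccc(C(=O)NCCC(=O)O)cc1)N1C(=O)C(c2cccc(Cl)c2F)=N[C@]12CC[C@@H](C(C)(C)C)CC2` differs from compound 2 by a single change: fluoro in place of hydrogen on an aromatic carbon. Two measured steps offer some guidance. an 8.5-fold lower number from compound 1 to compound 2 (0.93 log units; beyond the scatter), but that swap changed the halogen and its place at once, so it does not isolate a fluoro. a 5.9-fold higher number from compound 2 to compound 3 (0.77 log units; beyond the scatter) concerns a different part of the molecule. Among the measured compounds shown here, no step shows a fluoro entering while the chloro stays. The expected step is a 1.4-fold higher number from compound 2 to compound 4 (0.14 log units; within the scatter), small and possibly within the scatter. The estimate for compound 4 is 180 nM, with a range from 70 nM to 450 nM.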

Compound 4, half-maximal inhibitory concentration: 620 nM
Beside the measured number, compound 4's estimate is 3.4-fold (0.54 log units) below it, and the stated range ends below it.
By their numbers in this assay, from the lowest: compound 2; then compounds 4, 3 and 1 (each within the scatter of the next).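

In this assay, among these compounds, the fluoro, ortho to a chloro group, gives a 4.8-fold higher number from compound 2 to compound 4 (0.68 log units; beyond the scatter) and this is the first step showing a fluoro entering while the chloro stays, so even this single atom is not a neutral addition at this aromatic carbon. With the fluoro present, adding the chloro gives a 1.8-fold lower number from compound 1 to compound 4 (0.25 log units; within the scatter) and so the low number of the 3-chlorophenyl in compound 2 does not carry over to compound 4. Nothing available explains this result.

Going by these compounds, whether the rise belongs to fluoro itself or to any group on this carbon stays open; a methoxy or a nitrile there could help tell these apart.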